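Adding One Carbon to the Acid Chain of Compound 3

The compounds below may be only part of what the source reports. "The series", "measured", "known", "first", "only" and "open" are said of these compounds alone.

In a functional assay on MCF7 cells (Homo sapiens) for antiproliferative activity, read by MTT assay, with a stated time of 72 h (a lower number here means a stronger inhibitor, a higher number a weaker inhibitor), compound 3 `CCn1cc(C(CC)(CC)c2ccc(C#CC(O)(CC)CC)c(C)c2)cc1C(=O)NCC(=O)O` gives 17500 nM and compound 1 `CCn1cc(C(CC)(CC)c2ccc(C#CC(O)(CC)CC)c(C)c2)cc1C(=O)NCCN(C)C` gives 13400 nM, so the two stand level. Compound 2 `CCCCC(=O)c1cc(C(CC)(CC)c2ccc(C#CC(O)(CC)CC)c(C)c2)cn1CC` gives > 50000 nM, which is a limit of the assay and not a number.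

Compound 4 `CCn1cc(C(CC)(CC)c2ccc(C#CC(O)(CC)CC)c(C)c2)cc1C(=O)NCCC(=O)O` keeps the shared core and alters only the amide side chain: carboxymethyl in place of carboxy on a saturated chain carbon bound to an amide-type nitrogen. This places carboxymethyl in place of carboxy on a saturated chain carbon bound to an amide-type nitrogen.

The closest guide is a 1.3-fold higher number from compound 1 to compound 3 (0.12 log units; within the scatter), a change at that same chain carbon, which stays within the scatter. The larger steps, an at least 3.7-fold higher number from compound 1 to compound 2 (0.57 log units; beyond the scatter) and an at least 2.8-fold lower number from compound 2 to compound 3 (0.45 log units; beyond the scatter), exchange the whole amino side chain with butyl on a carbonyl carbon, and compound 4 involves no such exchange.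

No step beyond the scatter is therefore expected in this assay, and the expected change is a 1.0-fold lower number from compound 3 to compound 4 (0.01 log units; within the scatter). For compound 4 the estimated value is 17000 nM, with an expected range of 8000 nM to 38000 nM.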

Compound 4, half-maximal inhibitory concentration: 30600 nM
Beside the measured number, compound 4's estimate is 1.8-fold (0.26 log units) below it; the measured number falls inside the stated range.
By their numbers in this assay, from the lowest: compounds 1, 3 and 4 (each within the scatter of the next, the first and the last beyond it). At a limit, above all of these: compound 2.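

In this assay, the extra carbon leaves the acid chain's effect unresolved, with a 1.7-fold higher number from compound 3 to compound 4 (0.24 log units; within the scatter). Compound 4 does, however, give the first acid-against-amine difference beyond the scatter, with a 2.3-fold higher number from compound 1 to compound 4 (0.36 log units; beyond the scatter), whereas the shorter acid gave a 1.3-fold higher number from compound 1 to compound 3 (0.12 log units; within the scatter). With (2-carboxyethyl)amino in place of butyl on a carbonyl carbon, the step reads an at least 1.6-fold lower number from compound 2 to compound 4 (0.21 log units; that floor lies within the scatter), and it rests on a value for compound 2 that is a limit of the assay and not a number: the limit of > 50000 nM in this assay, at which 1 of the 4 values shown sits.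

The compounds shown leave open whether a longer acid chain, such as 3-carboxypropyl, would continue the drift seen in the numbers or stay level with compound 4. They also leave open how a primary amine at the end of the chain would compare with the dimethylamino group of compound 1.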